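The source may report more compounds than this note shows. Statements on the series, on what has been measured and on what is new or still open speak of the compounds shown alone.

Measured compounds:
compound 1 `CC[C@@H]1C(=O)N(C)c2cnc(Nc3ccc(C(=O)NC4CCN(C)CC4)cc3OC)nc2N1C(C)C`, 4 nM
compound 2 `CCC[C@@H]1C(=O)N(C)c2cnc(Nc3ccc(C(=O)NC4CCN(C)CC4)cc3OC)nc2N1C1CCCC1`, 9.9 nM

In an assay on isolated protein for inhibition of serine/threonine-protein kinase PLK1 (Homo sapiens), read by Z'-LYTE (on this read-out higher numbers stand for weaker inhibition and lower numbers for stronger inhibition), compound 2 gives the higher of the two numbers and compound 1 the lower, a gap that lies beyond the usual scatter. Compound 3 `COc1cc(C(=O)NC2CCN(C)CC2)ccc1Nc1ncc2c(n1)N(C1CCCC1)[C@H](CC(C)C)C(=O)N2C` has not yet been measured. Relative to compound 2 the change is methyl in place of hydrogen on a saturated chain carbon bound to two saturated chain carbons. Among the measured compounds shown here, no measured pair of this kind exists here, so the step in this assay is expected to be small, slightly toward a higher number or none beyond the scatter. Compound 3 is therefore estimated at 13 nM, within 5 nM to 32 nM, which means a step of a 1.3-fold higher number from compound 2 to compound 3 (0.12 log units; within the scatter).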

Compound 3, half-maximal inhibitory concentration: 78 nM
For compound 3 the middle estimate is 6.0-fold (0.78 log units) below the measured one; measured number above the stated range.
By their numbers in this assay, from the lowest: compound 1; then compound 2; then compound 3.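

In this assay, a single added methyl on a saturated chain carbon bound to two saturated chain carbons, turning propyl into isobutyl, gives a 7.9-fold higher number from compound 2 to compound 3 (0.90 log units; beyond the scatter) and so lies beyond the scatter. The earlier compounds shown here differed in more than one place and could not isolate a change at this chain alone. No measured evidence here accounts for the step. As far as these compounds go, whether a longer unbranched chain such as butyl would give a similar number remains open. So does the effect of an amine at the end of this chain.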